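Swapping a methylphenyl for a chlorophenyl on the triazole nitrogen

The source may report more compounds than this note shows. Statements on the series, on what has been measured and on what is new or still open speak of the compounds shown alone.

Compound 3 `Cc1cccc(-n2cc(-c3cccc(NS(=O)(=O)c4c[nH]c(=O)[nH]c4=O)c3)nn2)c1` was tested in a functional assay on A549 cells (Homo sapiens) for antiproliferative activity, read by MTT assay, with a stated time of 24 h (on this read-out lower numbers stand for stronger inhibition and higher numbers for weaker inhibition), and gave 3550 nM. That number lies within the scatter of compound 1 `Cc1ccc(-n2cc(-c3ccccc3NS(=O)(=O)c3c[nH]c(=O)[nH]c3=O)nn2)cc1`, which gave 2910 nM, and of compound 2 `O=c1[nH]cc(S(=O)(=O)Nc2ccccc2-c2cn(-c3cccc(Cl)c3)nn2)c(=O)[nH]1`, which gave 2340 nM. Compound 4 `O=c1[nH]cc(S(=O)(=O)Nc2cccc(-c3cn(-c4ccccc4Cl)nn3)c2)c(=O)[nH]1` is not yet measured; it differs from compound 3 by 2-chlorophenyl in place of 3-methylphenyl on an aromatic nitrogen. For the measured compounds named here, the one measured step of a similar kind, a 1.2-fold lower number from compound 1 to compound 2 (0.09 log units; within the scatter), exchanged a methylphenyl for a chlorophenyl on the same ring nitrogen and stayed within the scatter, so no step beyond the scatter is expected here either, giving an expected 1.2-fold lower number from compound 3 to compound 4 (0.07 log units; within the scatter). Compound 4 is therefore estimated at 3000 nM, with a range from 1200 nM to 7500 nM.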

Compound 4, half-maximal inhibitory concentration: 2730 nM
The estimate for compound 4 lay 1.1-fold (0.04 log units) above the measured number, and the stated range covers the measured number.
By their numbers in this assay, from the lowest: compounds 2, 4, 1 and 3 (each within the scatter of the next).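

The change from 3-methylphenyl to 2-chlorophenyl on the aromatic nitrogen gives a 1.3-fold lower number from compound 3 to compound 4 (0.11 log units; within the scatter) in this assay. This position has now taken two different chlorophenyl groups in place of two different methylphenyl groups without a step beyond the scatter. Nothing measured here explains why these exchanges move the number so little. Still open, from the compounds shown here alone, is whether something other than a substituted phenyl on this nitrogen, such as a cyclohexyl ring or a chain ending in an amine or a carboxylic acid, would produce a step beyond the scatter.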